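Swapping methoxy for methylsulfanyl on a thiophene carboxamide scaffold

This account rests on a few compounds, and the source may have more. Where it says the series, first, only, none or still open, it means among the compounds named here.

Measured compounds, in a functional assay on HL-60 cells (Homo sapiens) for antiproliferative activity, with a stated time of 24 h; on this read-out lower numbers stand for stronger inhibition and higher numbers for weaker inhibition:
- compound 1 `COc1ccccc1NC(=S)N1CCc2c(sc(NC(=O)c3ccccc3Cl)c2C(N)=O)C1` gives 40900 nM
- compound 2 `CSc1ccccc1NC(=S)N1CCc2c(sc(NC(=O)c3ccccc3Cl)c2C(N)=O)C1` gives 14600 nM
- compound 3 `COc1ccccc1C(=O)Nc1sc2c(c1C(N)=O)CCN(C(=S)Nc1ccccc1Cl)C2` gives 20800 nM

Compound 1 and compound 2 share one core and differ only in a single group: methylsulfanyl in place of methoxy on an aromatic carbon. This exchange gave a 2.8-fold lower number from compound 1 to compound 2 (0.45 log units; beyond the scatter), a modest but real improvement.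

Compound 3 is built from the same atoms as compound 1, joined differently, so the two cores are related but not in a way that is broken down here. Its value sits within the usual scatter of both compound 1 and compound 2, so no order among these three can be read from the numbers.

Compound 4 `CSc1ccccc1C(=O)Nc1sc2c(c1C(N)=O)CCN(C(=S)Nc1ccccc1Cl)C2` has not yet been measured in this assay. It differs from compound 3 by methylsulfanyl in place of methoxy on an aromatic carbon, the same change that separates compound 1 from compound 2. The place of the exchange is described in identical terms for both pairs, which is the main reason to expect a similar outcome. Still, the group sits in a different part of the molecule in compound 3, so the earlier step is only a rough guide.

On that basis, compound 4 is expected to show a 2.3-fold lower number from compound 3 to compound 4 (0.36 log units; beyond the scatter), somewhat smaller than the step seen from compound 1 to compound 2, giving an estimated value of 9000 nM, likely between 4000 nM and 20000 nM.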

Compound 4, half-maximal inhibitory concentration: 30500 nM
Estimate against measurement, compound 4: 3.4-fold (0.53 log units) below; the measured number lies above the stated range.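

In this assay, the exchange of methoxy for methylsulfanyl did not bring the same gain on the second core, where it gave a 1.5-fold higher number from compound 3 to compound 4 (0.17 log units; within the scatter), a step too small to separate from repeat-to-repeat variation. Set beside the earlier pair, the two outcomes really do differ: the same change on two cores in this assay, a 2.8-fold lower number (0.45 log units; beyond the scatter) from compound 1 to compound 2 and a 1.5-fold higher number (0.17 log units; within the scatter) from compound 3 to compound 4, 4.1-fold (0.61 log units) apart, beyond the scatter of two such steps. So the gain seen on the core of compound 1 cannot be assumed to carry over to the core of compound 3 even when the exchange is described in identical terms, although these two pairs do not show why the outcomes differ or how the exchange would behave on any other core in this series.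

The compounds shown leave open whether ethoxy, ethylsulfanyl or a single chlorine on that same aromatic carbon would follow the pattern of compound 1 and compound 2 or that of compound 3 and compound 4. They also leave open whether the two pairs would part in the same way in a read-out other than this assay, since a single cell-based measurement is all that is available for each compound here.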